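Clearance in the quinolizinone series: methyl to 4-fluorophenyl

The source may hold more compounds than are shown below. What is called first, only, known or untested is meant among the compounds shown, and "the series" means these compounds.

Measured compounds:
compound 1, `C[C@H](Nc1nc(N)nc(N)c1C#N)c1cc(=O)n2cc(F)ccc2c1-c1cc(F)cc(F)c1`: in an ADME assay on the whole organism (Mus musculus, strain BALB/C) for pharmacokinetics, read by LC-MS, with a stated time of 24 h, at a dose of 1 mg/kg by the intravenous route (a higher number here means faster removal of the compound, a lower number slower removal), compound 1 gives 18 mL/min/kg
compound 2, `Cc1c([C@H](C)Nc2nc(N)nc(N)c2C#N)c(-c2ccccc2)c(=O)n2cc(F)ccc12`: in this assay compound 2 gives 49 mL/min/kg

Compound 2 carries the highest of the two numbers in this assay; its nearest neighbour is compound 1, whose number is lower by an amount beyond the scatter. For the measured compounds named here, no pair of measured compounds differs in one place only, so no single step is known.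

Compound 3, `C[C@H](Nc1nc(N)nc(N)c1C#N)c1c(-c2ccccc2)c(=O)n2cc(F)ccc2c1-c1ccc(F)cc1`, is the next compound for this assay. It differs from compound 2 by 4-fluorophenyl in place of methyl on an aromatic carbon.

Nothing measured isolates this change. Compound 1, which also carries an aryl group on the core in place of a methyl, gives 18 mL/min/kg, so a drop from compound 2 is plausible, but the two compounds differ in more than one place. The expected step is a 1.6-fold lower number from compound 2 to compound 3 (0.21 log units; within the scatter), towards slower removal and of modest size. For compound 3 the estimate in this assay is 30 mL/min/kg, within 13 mL/min/kg to 70 mL/min/kg.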

Compound 3, clearance: 5.6 mL/min/kg
Estimate against measurement, compound 3: 5.4-fold (0.73 log units) above, outside the stated range (below it).
By their numbers in this assay, from the lowest: compound 3; then compound 1; then compound 2.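

In this assay, for the compounds shown here, 4-fluorophenyl in place of methyl on this aromatic carbon gives an 8.8-fold lower number from compound 2 to compound 3 (0.94 log units; beyond the scatter), the first step that isolates a single change. It shows that what sits at this position, ortho to a fused ring and two atoms from the ring nitrogen, can shift the clearance well beyond the scatter, and that the larger aromatic group here goes with slower removal. Nothing available explains the size of this step.

On these data alone, whether the step belongs to the aromatic ring or to its fluorine remains open, and a plain phenyl or a cyclohexyl ring on this carbon would separate the two. Equally open, as far as these compounds go, is how an amine, a carboxylic acid or a longer alkyl chain at this position would read in this assay.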